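The source may hold more compounds than are shown below. What is called first, only, known or untested is meant among the compounds shown, and "the series" means these compounds.

Compound 2, `COc1ccc(CCCC(=O)N2CCc3c(Cl)c(O)c(O)c(Cl)c3C2)nc1`, gives 96% in a functional assay (Homo sapiens), tested at 1 uM (a higher number here means a weaker effect of the compound at the concentration tested, a lower number a stronger effect), which is the higher of the two numbers recorded there, a number beyond the scatter above that of compound 1. Compound 1, `O=C(CCCc1ccc(C(F)(F)F)cn1)N1CCc2c(Cl)c(O)c(O)c(Cl)c2C1`, gives 72% in this assay. Among the measured compounds shown here, the one step measured so far, a number 24 percentage points higher from compound 1 to compound 2 (beyond the scatter), connects these two compounds.

Compound 3, `CS(=O)(=O)c1ccc(CCCC(=O)N2CCc3c(Cl)c(O)c(O)c(Cl)c3C2)nc1`, is the compound not yet measured. It differs from compound 2 in one place: methylsulfonyl in place of methoxy on an aromatic carbon.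

For the measured compounds named here, the measured step from compound 1 to compound 2 bears on this change only in part, since it concerns the same aromatic carbon and the same methoxy group that now leaves, but the group that enters, methylsulfonyl, appears in no measured compound. With the methoxy group that took the number up by a number 24 percentage points higher from compound 1 to compound 2 (beyond the scatter) now gone, a step back toward the number of compound 1 in this assay seems plausible, but its size is uncertain. Compound 3 is therefore expected to show a downward step of a number 12 percentage points lower from compound 2 to compound 3 (beyond the scatter). Compound 3 is estimated at 84%, within a range from 64% to 100%.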

Compound 3, a percentage reported as activity, at one concentration (the size of the read-out at that concentration, not a potency): 99%
Estimate against measurement, compound 3: 15 percentage points below; the range from low to high includes it.
By their numbers in this assay, from the lowest: compound 1; then compounds 2 and 3 (each within the scatter of the next).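

In this assay, placing methylsulfonyl for methoxy on this aromatic carbon, two atoms from the ring nitrogen and para to a large group, gives a number 3 percentage points higher from compound 2 to compound 3 (within the scatter) and so does not separate the two groups, although methylsulfonyl is the larger of them, with 4 heavy atoms against 2. The comparison with the trifluoromethyl compound gives a number 27 percentage points higher from compound 1 to compound 3 (beyond the scatter) as a second step beyond the scatter, so among the three groups seen at this position, trifluoromethyl alone goes with the lower number, while methoxy and methylsulfonyl both go with the higher one. No measurement shown here explains why these groups fall out this way.

The compounds shown leave open whether a nitrile, a chlorine atom or a simple methyl group on this carbon would group with trifluoromethyl or with methoxy and methylsulfonyl. They also leave open whether the same ordering of these groups would hold if the chain joining this ring to the amide carbonyl were replaced by a longer chain.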